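Boronic acid series: pKa notes ahead of compound 4

This account rests on a few compounds, and the source may have more. Where it says the series, first, only, none or still open, it means among the compounds named here.

Measured so far:
compound 1, `[N-]=[N+]=Nc1cc(B(O)O)c(F)cc1F`, 6.27
compound 2, `[N-]=[N+]=Nc1ccc(F)c(B(O)O)c1`, 6.87
compound 3, `OB(O)c1cc(-n2cc(-c3ccsc3)nn2)c(F)cc1F`, 6.27

Values come from a physicochemical assay for acid dissociation, read by spectrophotometry, in phosphate buffer, at pH 4.3, tested at 0.1 mM. Compound 2 differs from compound 1 by hydrogen in place of fluoro on an aromatic carbon, and the step is a number 0.60 log units higher from compound 1 to compound 2 (beyond the scatter). Compound 3 stands level with compound 1 within the scatter; how the core of compound 3 differs from the core of compound 1 is not broken down here. Against compound 2, compound 3 sits lower by the same gap that separates compound 1 from compound 2.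

Compound 4, `OB(O)c1cc(-n2cc(-c3ccsc3)nn2)ccc1F`, is not yet measured in this assay. It differs from compound 3 by hydrogen in place of fluoro on an aromatic carbon. This is the same kind of change as that from compound 1 to compound 2, not the same: there the leaving fluoro stood ortho to an azido group (3 heavy atoms), here it stands ortho to a large group; the meta and para surroundings read alike.

On the strength of a number 0.60 log units higher from compound 1 to compound 2 (beyond the scatter), the step from compound 3 to compound 4 is expected to be a number 0.60 log units higher from compound 3 to compound 4 (beyond the scatter). Among the compounds with values here, compound 4 is estimated at 6.87, with a likely range from 6.55 to 7.2, resting on the single measured instance of this change.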

Compound 4, acid dissociation constant: 7.61
Compound 4: middle estimate off by 0.74 log units, on the low side; measured number above the stated range.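

In this assay, hydrogen in place of fluoro gives a number 1.34 log units higher from compound 3 to compound 4 (beyond the scatter) on one core and a number 0.60 log units higher from compound 1 to compound 2 (beyond the scatter) on the other, so the direction of the step carries across these two pairs while its size does not. Two pairs show that a step measured on one core cannot be treated as a fixed increment on another in this series, but they do not establish a general rule or a typical size for the change. Nothing available explains why the two steps differ in size.

Still open, as far as these compounds go, is whether the size of the step follows the group standing ortho to the leaving fluoro, since the two pairs offer only an azido group and one large group in that place. An amine or a carboxylic acid there, with and without the fluoro, would show whether the step stays in the same direction and how far its size moves.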